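Changing the nitrogen group of compound 2

The source may report more compounds than this note shows. Statements on the series, on what has been measured and on what is new or still open speak of the compounds shown alone.

Going by the values given here, in an ADME assay on C8166 cells (Homo sapiens) for cytotoxicity, read by MTT assay (a lower number here means that less compound is tolerated, a higher number that more compound is tolerated), compound 2 `O=C(O)c1cn(-c2ccc(Br)cc2)c2ccc(Cc3cccc(Cl)c3F)c(O)c2c1=O` gives 85000 nM, the lower of the two numbers so far. The other measured compound, compound 1 `Cc1ccc(-n2cc(C(=O)O)c(=O)c3c(O)c(Cc4cccc(Cl)c4F)ccc32)cc1C`, gives 316000 nM. The next compound to be tested, compound 3 `O=C(O)c1cn(Cc2ccccc2F)c2ccc(Cc3cccc(Cl)c3F)c(O)c2c1=O`, keeps the shared core and carries 2-fluorobenzyl in place of 4-bromophenyl on an aromatic nitrogen. Among the compounds with values here, one measured step bears on this change, as it also swapped the group on that nitrogen: a 3.7-fold lower number from compound 1 to compound 2 (0.57 log units; beyond the scatter). That step is modest but beyond the scatter. Within the data shown here, no measured compound carries a benzyl group, so it offers a rough size and no firm direction. A step of similar or smaller size is therefore expected, perhaps slightly upward. The estimate amounts to an expected 1.4-fold higher number from compound 2 to compound 3 (0.15 log units; within the scatter). For compound 3 the expected value is 120000 nM, with an estimated range of 40000 nM to 350000 nM.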

Compound 3, half-maximal cytotoxic concentration: 44900 nM
The estimate for compound 3 lay 2.7-fold (0.43 log units) above the measured number, within the range that was stated.
By their numbers in this assay, from the lowest: compounds 3 and 2 (each within the scatter of the next); then compound 1.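

In this assay, replacing 4-bromophenyl with 2-fluorobenzyl on the nitrogen gives a 1.9-fold lower number from compound 2 to compound 3 (0.28 log units; within the scatter), so this change cannot be told apart from the ordinary variation between repeat measurements. Replacing 3,4-dimethylphenyl with the same benzyl group gives a 7.0-fold lower number from compound 1 to compound 3 (0.85 log units; beyond the scatter). The earlier step to 4-bromophenyl was also beyond the scatter. Compound 1 now stands apart from both other compounds, with the highest number of the three. Nothing available explains why the 3,4-dimethylphenyl compound differs in this way.

An unsubstituted benzyl group would show whether the fluorine in 2-fluorobenzyl matters to the number at all. As far as these compounds go, it also remains open where a nitrogen group with no aromatic ring, such as a short alkyl chain or one ending in an amine, would fall relative to these three compounds.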